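From Cyclohexyl to 4-Nitrophenoxy: One Amide Substituent Exchanged

The source may report more compounds than this note shows. Statements on the series, on what has been measured and on what is new or still open speak of the compounds shown alone.

Measured so far in an ADME assay on BJ cells (Homo sapiens) for antiproliferative activity, with a stated time of 72 h; a lower number here means that less compound is needed, a higher number that more compound is needed for the effect:
Compound 1 `COc1ccc(-c2c(Br)c(=O)c3c(OC)cc(OC)cc3n2S(=O)(=O)c2ccc(OC)cc2)cc1` gives 49700 nM.
Compound 2 `COC(=O)c1cc(=O)c2c(OC)cc(OC)cc2[nH]1` reaches only a limit of the assay, > 34400 nM.
Compound 3 `COc1cc(OC)c2c(=O)cc(C(=O)Nc3ccc(C4CCCCC4)cc3)[nH]c2c1` gives 36200 nM.

Compound 3 holds the lowest of the two numbers in this assay, yet the nearest of them, that of compound 1, lies within the usual scatter of repeated measurements, so the two cannot be told apart. For compound 2 the result is the limit of > 34400 nM in this assay, at which 1 of the 3 values shown sits. Going by the values given here, all three compounds therefore sit in the same weak region, with no step among them that stands out.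

The unmeasured compound 4 `COc1cc(OC)c2c(=O)cc(C(=O)Nc3ccc(Oc4ccc([N+](=O)[O-])cc4)cc3)[nH]c2c1` departs from compound 3 in a single place: 4-nitrophenoxy in place of cyclohexyl on an aromatic carbon, in words, 4-nitrophenoxy in place of cyclohexyl on an aromatic carbon. Among the compounds with values here, no measured pair isolates this exchange, and the closest guide is the narrow spread seen for compound 1, compound 2 and compound 3. On that basis the expected step is a 1.0-fold lower number from compound 3 to compound 4 (0.00 log units; within the scatter), which amounts to no change beyond the scatter. Compound 4 is estimated at 36000 nM, with a range from 15000 nM to 90000 nM.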

Compound 4, half-maximal effective concentration: > 22900 nM
Compound 4: only a limit was reported; the forecaster's own chance of this, stated with the estimate: 30%; the middle value does not contradict the limit.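

In this assay compound 4 reaches only a limit of the assay, > 22900 nM. The step between compound 3 and compound 4 therefore cannot be read, and no size can be given for 4-nitrophenoxy in place of cyclohexyl. The compounds shown leave open whether this exchange changes the number in this assay at all.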